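Adding a Second Trifluoromethyl Group: Cytotoxicity in Two Series

A few compounds are considered here, and "the series" means these few. Any claim that something is new, unique, unknown or untested is made for them only; others in the source may bear on it.

Measured compounds:
compound 1, `Cc1cc(NC(=O)c2cccc(C(F)(F)F)c2)ccc1NS(C)(=O)=O`, 194000 nM
compound 2, `Cc1cc(NC(=O)c2cc(C(F)(F)F)cc(C(F)(F)F)c2)ccc1NS(C)(=O)=O`, 163000 nM
compound 3, `O=C(Nc1ccc(NS(=O)(=O)C(F)(F)F)c(Cl)c1)c1cccc(C(F)(F)F)c1`, 210000 nM

The three measured compounds were tested in an ADME assay on HEK293 cells (Homo sapiens) for cytotoxicity, read by MTT assay, with a stated time of 48 h; on this read-out higher numbers stand for weaker inhibition and lower numbers for stronger inhibition. In this assay compound 1 gives 194000 nM, compound 2 gives 163000 nM and compound 3 gives 210000 nM. Among the measured compounds shown here, the three numbers lie close together, and no step between them is printed as beyond the scatter, so none of the three can be called more or less cytotoxic than another.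

Compound 1 and compound 2 differ in one place: trifluoromethyl in place of hydrogen on an aromatic carbon. This change gave a 1.2-fold lower number from compound 1 to compound 2 (0.08 log units; within the scatter).

Compound 3 carries a different core; how its core differs from that of compound 1 is not broken down here.

Compound 4, `O=C(Nc1ccc(NS(=O)(=O)C(F)(F)F)c(Cl)c1)c1cc(C(F)(F)F)cc(C(F)(F)F)c1`, has not yet been measured in this assay. It differs from compound 3 by trifluoromethyl in place of hydrogen on an aromatic carbon. This is the same change that separates compound 1 from compound 2, and the surroundings of the place are described in the same words for both pairs.

Because the earlier step of a 1.2-fold lower number from compound 1 to compound 2 (0.08 log units; within the scatter) stayed within the scatter, the step from compound 3 to compound 4 is expected to be of a similar, small size, a 1.2-fold lower number from compound 3 to compound 4 (0.07 log units; within the scatter). Compound 4 is therefore estimated at 180000 nM in this assay, with a range from 90000 nM to 360000 nM.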

Compound 4, half-maximal inhibitory concentration: > 250000 nM
Compound 4: no number, only a limit; the forecaster's own chance of this, stated with the estimate: 20%; middle value at least 1.3-fold (0.14 log units) away from the limit.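

In this assay compound 4 gives > 250000 nM, which is a limit of the assay and not a number. Read against its partner on the same core, this yields an at least 1.1-fold higher number from compound 3 to compound 4 (0.07 log units; that floor lies within the scatter), so trifluoromethyl in place of hydrogen on an aromatic carbon has only a floor on this core, and that floor cannot show whether the change carries over from the other core unaltered: the same change on two cores in this assay, a 1.2-fold lower number (0.08 log units; within the scatter) from compound 1 to compound 2 and an at least 1.1-fold higher number (0.07 log units; that floor lies within the scatter) from compound 3 to compound 4; the limit leaves it open whether they differ The pair therefore shows neither that the change transfers between these two cores nor that it fails to, and the true size of the step on the core of compound 3 remains unread, with a single compound resting on that limit: the limit of > 250000 nM in this assay, at which 1 of the 4 values shown sits.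

The compounds shown leave open whether a different group entering at the same place, such as a nitrile, a methoxy group or an amine, would give a step that could be read in full on both cores. As far as these compounds go, how the chlorine and the methyl group on the two cores each weigh on their own in this assay also remains open.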